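This account rests on a few compounds, and the source may have more. Where it says the series, first, only, none or still open, it means among the compounds named here.

Among the measured compounds shown here, in an ADME assay on HeLa Rh cells (Homo sapiens) for cytotoxicity, read by microscopy (on this read-out lower numbers stand for higher toxicity in this test and higher numbers for lower toxicity in this test), compound 2 `COc1cc(CC(O)c2ccc(-c3cccc(Cl)c3)cc2)c([N+](=O)[O-])cc1OC` gives 5900 nM, which is the only actual number recorded in this assay among the two compounds measured. Compound 1 `COc1cc(CC(O)c2ccc(-c3ccc(C=O)cc3)cc2)c([N+](=O)[O-])cc1OC` reaches only a limit in this assay, > 245000 nM, and no number is known for it. That value sits at the limit of > 245000 nM in this assay, at which 1 of the 2 values shown sits. For the measured compounds named here, the single measured step is an at least 41-fold lower number from compound 1 to compound 2 (1.61 log units; beyond the scatter), and it exchanges a 4-formylphenyl for a 3-chlorophenyl, a change far broader than the one now in question. Compound 3 `COc1cc(CC(O)c2ccc(-c3cccc(F)c3)cc2)c([N+](=O)[O-])cc1OC` differs from compound 2 by fluoro in place of chloro on an aromatic carbon. Going by the values given here, no measured step swaps one halogen for another, so the measured step bears on the present one only in showing that a 3-chlorophenyl at this place yields a number in this assay rather than a limit. A step of size a 1.5-fold higher number from compound 2 to compound 3 (0.18 log units; within the scatter) is expected, a shift toward a higher number that is not clearly beyond the scatter. Compound 3 is therefore estimated at 9000 nM in this assay, with a range from 3000 nM to 30000 nM.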

Compound 3, half-maximal cytotoxic concentration: 7400 nM
Compound 3: middle estimate off by 1.2-fold (0.09 log units), on the high side, and the stated range covers the measured number.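

In this assay, fluoro in place of chloro on this aromatic carbon gives a 1.3-fold higher number from compound 2 to compound 3 (0.10 log units; within the scatter), so the two halogens cannot be told apart at this position. The other comparison now available gives an at least 33-fold lower number from compound 1 to compound 3 (1.51 log units; beyond the scatter), which shows that the large separation from the 4-formylphenyl compound is not tied to the 3-chlorophenyl alone, since a 3-fluorophenyl at the same place also yields an actual number. Compound 1 thus remains the only one of the three compounds that reaches a limit rather than a number: the limit of > 245000 nM in this assay, at which 1 of the 3 values shown sits.

The compounds shown leave open whether a halogen is needed at all at this place, and whether a methoxy group, a nitrile or an amine there would give a number close to those of compound 2 and compound 3. They also leave open whether the limit reached by compound 1 goes with the formyl group itself or with where that group sits on the ring, and whether changes elsewhere on the shared core would move the number further than this exchange of halogens.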